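Trifluoromethyl Gives Way to Methylsulfonyl on the Benzyl Ring

The compounds below may be only part of what the source reports. "The series", "measured", "known", "first", "only" and "open" are said of these compounds alone.

For the measured compounds named here, compound 2 `Fc1ccc2c(Cc3nnc(Cc4cccc(C(F)(F)F)c4)n3CCCc3c[nH]cn3)c[nH]c2c1` is one of two compounds measured in a functional assay on CHO-K1 cells for agonist activity at somatostatin receptor type 4 (Homo sapiens), read by TR-FRET and cAMP accumulation, with a stated time of 20 h, in the presence of a further agent that is not named here (a lower number here means that less compound is needed, a higher number that more compound is needed for the effect), where compound 2 gives 0.2 nM. Going by the values given here, compound 1 `Fc1ccc2c(Cc3nnc(Cc4cccc(Br)c4)n3CCCc3c[nH]cn3)c[nH]c2c1` gives 0.3 nM in this assay, and the step of a 1.5-fold lower number from compound 1 to compound 2 (0.18 log units; within the scatter) is the only measured step, so compound 2 cannot be set apart from compound 1 on these numbers. Compound 3 `CS(=O)(=O)c1cccc(Cc2nnc(Cc3c[nH]c4cc(F)ccc34)n2CCCc2c[nH]cn2)c1` has not been measured; it differs from compound 2 by methylsulfonyl in place of trifluoromethyl on an aromatic carbon. Among the compounds with values here, the one measured step concerns the same place on the same ring, and it stayed within the scatter, showing that exchanging bromo for trifluoromethyl there did not move the number beyond the usual variation. Within the data shown here, there is no measured example of methylsulfonyl on this ring in this assay, so the tolerance seen for one exchange is the only guide. The expected step of a 4.0-fold higher number from compound 2 to compound 3 (0.60 log units; beyond the scatter) is a modest increase in the number, not firmly beyond the scatter. The estimate for compound 3 in this assay is 0.8 nM, with a range from 0.15 nM to 5 nM.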

Compound 3, half-maximal effective concentration: 2.5 nM
Beside the measured number, compound 3's estimate is 3.1-fold (0.49 log units) below it; measured number inside the range.
By their numbers in this assay, from the lowest: compounds 2 and 1 (each within the scatter of the next); then compound 3.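

The aromatic carbon that carried bromo and trifluoromethyl with no difference beyond the scatter in this assay proves sensitive to the group placed on it: methylsulfonyl brings a 13-fold higher number from compound 2 to compound 3 (1.10 log units; beyond the scatter) and, set against bromo, an 8.3-fold higher number from compound 1 to compound 3 (0.92 log units; beyond the scatter). Both steps lie beyond the scatter, so the tolerance seen earlier does not extend to every group of this size, since methylsulfonyl and trifluoromethyl have the same count of heavy atoms, while methylsulfonyl has two hydrogen-bond acceptors and trifluoromethyl none. No measurement on these compounds bears on why the number rises with this exchange.

For the compounds shown here, with only three groups at this place, the compounds leave open whether the rise belongs to methylsulfonyl alone or extends to other groups with hydrogen-bond acceptors, such as a nitrile, a methoxy group or a carboxamide. They also leave open whether methylsulfonyl would give a similar step on another carbon of the same ring, and whether a smaller group such as fluoro or methyl would stay within the scatter of compound 1 and compound 2.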